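Swapping Ethoxy for Isopropylamino: Expected Cytotoxicity

This account rests on a few compounds, and the source may have more. Where it says the series, first, only, none or still open, it means among the compounds named here.

Three compounds sharing one core have been measured in an ADME assay on CCRF-HSB-2 cells (Homo sapiens) for cytotoxicity, with a stated time of 7 days; on this read-out higher numbers stand for lower toxicity in this test and lower numbers for higher toxicity in this test:

Compound 1 `CCCCCCCCSc1nc(N)nc2c1ncn2/C=C1/CC1(CO)CO` gives 60000 nM.
Compound 2 `Nc1nc(OCc2ccccc2)c2ncn(/C=C3/CC3(CO)CO)c2n1` reaches only the assay limit, > 20000 nM.
Compound 3 `CCOc1nc(N)nc2c1ncn2/C=C1/CC1(CO)CO` likewise reaches only the assay limit, > 20000 nM.

Because two of the three values sit at the limit of > 20000 nM in this assay, at which 2 of the 3 values shown sit, the measured steps cannot be sized: a step that the limit leaves unreadable from compound 1 to compound 2, a step that the limit leaves unreadable from compound 1 to compound 3 and a step that the two limits leave unreadable from compound 2 to compound 3 all stay unreadable. Compound 3 thus stands at the limit, with no number of its own. Compound 4 `CC(C)Nc1nc(N)nc2c1ncn2/C=C1/CC1(CO)CO` differs from it by isopropylamino in place of ethoxy on an aromatic carbon. For the measured compounds named here, no measured step bears on this change with a readable size, so no shift beyond the scatter is expected in either direction; the estimated step that the limit leaves unreadable from compound 3 to compound 4 is expected to stay small. Compound 4 is therefore expected to give about 40000 nM, between 15000 nM and 120000 nM, most likely reported again only as a limit.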

Compound 4, half-maximal cytotoxic concentration: > 20000 nM
Compound 4 gave a limit, no number (the forecaster's own chance of this, stated with the estimate: 70%); the middle value lies beyond the limit too.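

For the compounds shown here, compound 4 also stops at the assay limit, so no step from compound 1, compound 2 or compound 3 to compound 4 can be read: the limit of > 20000 nM in this assay, at which 3 of the 4 values shown sit. From the compounds shown here alone, how far compound 2, compound 3 and compound 4 truly lie apart in this assay stays open.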